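Swapping Methyl for Fluoro on a Topoisomerase Inhibitor Scaffold

The compounds below may be only part of what the source reports. "The series", "measured", "known", "first", "only" and "open" are said of these compounds alone.

Three compounds have been measured in an assay on isolated protein for inhibition of DNA topoisomerase 1 (Homo sapiens), with a stated time of 30 min, tested at 100 uM; a higher number here means a stronger effect of the compound at the concentration tested, a lower number a weaker effect:
Compound 1, `Cc1cccc(-c2nc3cc(C)ccc3c(=O)[nH]2)c1`: 100%
Compound 2, `Cc1ccc2nc(-c3ccccc3C)[nH]c(=O)c2c1`: 0%
Compound 3, `Cc1ccc2nc(-c3ccccc3F)[nH]c(=O)c2c1`: 67.9%

Compound 1 stands highest of the three in this assay, with compound 3 nearest and compound 2 furthest. Compound 1 and compound 2 are built from the same atoms joined differently; how the two cores differ is not broken down here.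

Between compound 2 and compound 3 one change is made, (fluoro in place of methyl on an aromatic carbon), and it moved the read-out by a number 67.9 percentage points higher from compound 2 to compound 3 (beyond the scatter). The unmeasured compound 4, `Cc1ccc2c(=O)[nH]c(-c3cccc(F)c3)nc2c1`, carries the same kind of change relative to compound 1, namely (fluoro in place of methyl on an aromatic carbon). The two changes are not the same: in compound 3 the fluoro sits ortho to a large group, in compound 4 it sits meta to a large group.

Compound 1 already gives 100%, so the read-out cannot rise further. Compound 4 is expected to stay high, a step of about a number 20 percentage points lower from compound 1 to compound 4 (beyond the scatter), because compound 3 reaches 67.9% with fluoro in place of methyl. Compound 4 is therefore estimated at 80%, within 45% to 100%.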

Compound 4, a percentage reported as inhibition, at one concentration (the size of the read-out at that concentration, not a potency): 77.5%
Beside the measured number, compound 4's estimate is 2.5 percentage points above it; the measured number falls inside the stated range.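

In this assay, fluoro in place of methyl gives a number 22.5 percentage points lower from compound 1 to compound 4 (beyond the scatter), so a change that raised the read-out on one core lowers it on the other, and neither its size nor its direction carries over: the same change on two cores in this assay, a number 67.9 percentage points higher (beyond the scatter) from compound 2 to compound 3 and a number 22.5 percentage points lower (beyond the scatter) from compound 1 to compound 4, 90.4 percentage points apart, beyond the scatter of two such steps

The two steps also start from opposite ends of the scale, since compound 2 gives 0% while compound 1 gives 100%, which leaves no room for a rise. What this does not show is why the steps differ: the swap sits at a different place on the aromatic ring in the two pairs, the cores differ as well, and two pairs tested at one concentration cannot separate these factors or say anything about potency.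

Still open, from the compounds shown here alone, is whether a chloro, a methoxy or an amine at the same place would behave like fluoro or like methyl. Also open, going by these compounds, is what the swap would do at both places on one and the same core.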